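The source may report more compounds than this note shows. Statements on the series, on what has been measured and on what is new or still open speak of the compounds shown alone.

Measured so far:
Compound 1, `C=C1CC[C@@H]2[C@](C)(CO)[C@H](O)CC[C@@]2(C)[C@@H]1/C=C/C1=C/C(=C/C=C(/C)CCC=C(C)C)OC1=O` — "not active" (no number reported)
Compound 2, `C=C1CC[C@@H]2[C@](C)(CO)[C@H](O)CC[C@@]2(C)[C@@H]1/C=C/C1=C/C(=C/c2cccc(Br)c2)OC1=O` — 16.7%

Among the compounds with values here, in an assay on isolated protein for inhibition of Maltase-glucoamylase (Homo sapiens), tested at 100 uM (a lower number here means less inhibition, a higher number more inhibition at the concentration tested (going by the name of the read-out)), compound 2 gives 16.7%, and this is the only number in the set, since compound 1 is reported in this assay only as "not active" (no number reported) with no figure attached. Compound 2 therefore stands alone as the sole quantified point. Compound 3, `C=C1CC[C@@H]2[C@](C)(CO)[C@H](O)CC[C@@]2(C)[C@@H]1/C=C/C1=C/C(=C/C=C/c2ccccc2)OC1=O`, is not yet measured; it differs from compound 2 by 2-phenylethenyl in place of 3-bromophenyl on a double-bonded chain carbon bound to a double-bonded ring carbon. Within the data shown here, no step between measured compounds is available to guide the size of this change, so the expectation rests on the single value of compound 2 alone. A step from compound 2 to compound 3 of a number 3.7 percentage points lower from compound 2 to compound 3 (within the scatter) is expected, a move that stays within the usual scatter and may well amount to nothing. Compound 3 is estimated at 13% in this assay, with a range from 0% to 30%.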

Compound 3, a percentage reported as inhibition, at one concentration (the size of the read-out at that concentration, not a potency): 84.3%
For compound 3 the middle estimate is 71.3 percentage points below the measured one; the measured number lies above the stated range.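

In this assay, 2-phenylethenyl in place of 3-bromophenyl on a double-bonded chain carbon bound to a double-bonded ring carbon gives a number 67.6 percentage points higher from compound 2 to compound 3 (beyond the scatter), so the read-out at the shared core depends strongly on the group at this place. Both groups carry one six-membered aromatic ring of carbon only, so that ring alone does not secure the higher number; they differ in the bromine that leaves and the double bond outside aromatic rings that enters. Nothing available explains why this change has so large an effect.

The compounds shown do not separate the contribution of the bromine from that of the added double bond. They also leave open how the read-out would respond to a longer chain ending in the aromatic ring, or to an amine or a carboxylic acid on that ring.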